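Fluoro in Place of Chloro on Compound 3

The compounds below may be only part of what the source reports. "The series", "measured", "known", "first", "only" and "open" are said of these compounds alone.

Compound 1 `O=S(=O)(NCCCNc1nccc(-c2c(-c3cccc(F)c3)nc3sccn23)n1)c1ccc(Br)cc1`: in a functional assay on SK-MEL-28 cells (Homo sapiens) for cytotoxicity, read by MTT assay (on this read-out lower numbers stand for stronger inhibition and higher numbers for weaker inhibition), compound 1 gives 9400 nM.
Compound 2 `COc1ccc(S(=O)(=O)NCCCNc2nccc(-c3c(-c4cccc(F)c4)nc4sccn34)n2)cc1`: in this assay compound 2 gives 8980 nM.
Compound 3 `O=C(NCCCNc1nccc(-c2c(-c3cccc(F)c3)nc3sccn23)n1)c1ccc(Cl)cc1`: in this assay compound 3 gives > 20000 nM, which is a limit of the assay and not a measured number.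

Compound 3 is the one of the three whose value is unresolved; it stands at the limit of > 20000 nM in this assay, at which 1 of the 3 values shown sits. Compounds 1 and 2 sit close together: a 1.0-fold lower number from compound 1 to compound 2 (0.02 log units; within the scatter). Going from either to compound 3 raised the number: an at least 2.1-fold higher number from compound 1 to compound 3 (0.32 log units; beyond the scatter) and an at least 2.2-fold higher number from compound 2 to compound 3 (0.34 log units; beyond the scatter). Among the compounds with values here, these are the only measured steps that involve compound 3, and none of them tests the change now considered. Compound 4 `O=C(NCCCNc1nccc(-c2c(-c3cccc(F)c3)nc3sccn23)n1)c1ccc(F)cc1` differs from compound 3 only in fluoro in place of chloro on an aromatic carbon. Within the data shown here, no measured step swaps one halogen for another, so nothing here points to a move beyond the scatter in either direction. Compound 4 is therefore expected to stay near compound 3, with a step that the limit leaves unreadable from compound 3 to compound 4, and a limit is again the likelier outcome. As an estimate, compound 4 is expected at 25000 nM, within 11000 nM to 60000 nM.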

Compound 4, half-maximal inhibitory concentration: > 20000 nM
Compound 4 gave a limit, no number; the forecaster's own chance of this, stated with the estimate: 70%; the middle value does not contradict the limit.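

In this assay compound 4 stands at a limit and not at a number, as compound 3 does, so the step between them cannot be read: the limit of > 20000 nM in this assay, at which 2 of the 4 values shown sit.

What the result adds is that the gap to the sulfonyl compounds also holds with 4-fluorophenyl on the carbonyl: an at least 2.2-fold higher number from compound 2 to compound 4 (0.34 log units; beyond the scatter) and an at least 2.1-fold higher number from compound 1 to compound 4 (0.32 log units; beyond the scatter). Changing chloro to fluoro at this position therefore did not bring the carbonyl series back into the readable range, and among these four compounds none goes against the sulfonyl compounds giving the lower numbers.

From the compounds shown here alone, it remains open whether the two halogens differ at all beyond the limit. Also open, going by these compounds, is whether an amine or a carboxylic acid in that place on the ring, or a longer chain in the linker, would give the carbonyl series a readable value.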